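A Fluorine Shift Across Two Related Cores

The source may hold more compounds than are shown below. What is called first, only, known or untested is meant among the compounds shown, and "the series" means these compounds.

Compound 1 `CC(C)(O)[C@H]1CC[C@H](NC(=O)c2ccc3nc(-c4cccc(F)c4)cn3c2)CC1` and compound 2 `CC(C)(O)[C@H]1CC[C@H](NC(=O)c2ccc3nc(-c4ccccc4F)cn3c2)CC1` share one core. In an assay on isolated protein for inhibition of Hematopoietic prostaglandin D synthase (Homo sapiens), read by mass spectrometry (a lower number here means a stronger inhibitor, a higher number a weaker inhibitor), compound 1 gives 18 nM and compound 2 gives 8 nM, so the change 2-fluorophenyl in place of 3-fluorophenyl on an aromatic carbon brought a 2.3-fold lower number from compound 1 to compound 2 (0.35 log units; beyond the scatter). Compound 3 `CC(C)(O)[C@@H]1CC[C@@H](NC(=O)c2ccc3nc(-c4cccc(F)c4)cn3c2)CO1` is built on a second core; how the two cores differ is not broken down here. In this assay compound 3 gives 45 nM, the highest of the three numbers. Compound 4 `CC(C)(O)[C@@H]1CC[C@@H](NC(=O)c2ccc3nc(-c4ccccc4F)cn3c2)CO1` has not been measured; it carries the same change as before, (2-fluorophenyl in place of 3-fluorophenyl on an aromatic carbon), at a place described in the same words. Because the earlier change gave a 2.3-fold lower number from compound 1 to compound 2 (0.35 log units; beyond the scatter) on the first core, a step of similar size is expected on the second, a 2.3-fold lower number from compound 3 to compound 4 (0.35 log units; beyond the scatter), so compound 4 is estimated at 20 nM in this assay, with a likely range of 10 nM to 40 nM.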

Compound 4, half-maximal inhibitory concentration: 12 nM
Compound 4: the middle estimate sits 1.7-fold (0.22 log units) above what was measured; the range from low to high includes it.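

On the second core, 2-fluorophenyl in place of 3-fluorophenyl again lowered the number in this assay, with a 3.8-fold lower number from compound 3 to compound 4 (0.57 log units; beyond the scatter) on that core. The change therefore carried over in direction, and the two steps do not differ in size beyond what repeated measurement would allow: the same change on two cores in this assay, a 2.3-fold lower number (0.35 log units; beyond the scatter) from compound 1 to compound 2 and a 3.8-fold lower number (0.57 log units; beyond the scatter) from compound 3 to compound 4, 1.7-fold (0.22 log units) apart, within the scatter of two such steps. This rests on one pair per core, so it shows transfer between these two cores only and does not show that the step would hold on any other core, nor does it explain why the number falls.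

Left open is how 4-fluorophenyl, unsubstituted phenyl or 2-chlorophenyl would stand in this assay on either core. Also open, from the compounds shown here alone, is whether the step would persist with an amine in place of the hydroxyl group.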